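This account rests on a few compounds, and the source may have more. Where it says the series, first, only, none or still open, it means among the compounds named here.

Measured so far in a functional assay on HepG2 cells (Homo sapiens) for antiproliferative activity, read by MTT assay, with a stated time of 48 h; on this read-out lower numbers stand for stronger inhibition and higher numbers for weaker inhibition:
- compound 1 `COc1ccc(-c2ccc3c(c2)C(=O)C(=O)N3c2ccc(OC)cc2)cc1`: > 10000 nM
- compound 2 `COc1ccc(-c2ccc3c(c2)C(=O)C(=O)N3Cc2cccc(Cl)c2)cc1`: 320 nM
- compound 3 `COc1ccc(CN2C(=O)C(=O)c3cc(-c4cccc(OC)c4)ccc32)cc1`: 1890 nM

The entry for compound 1 is a limit of the assay, not a number. Compound 3, at 1890 nM, holds the higher of the two true numbers, and compound 2 gives 320 nM, a gap beyond the scatter.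

Next comes compound 4 `COc1ccc(CN2C(=O)C(=O)c3cc(-c4ccc(C(C)(C)C)cc4)ccc32)cc1`, with 4-(tert-butyl)phenyl in place of 3-methoxyphenyl on an aromatic carbon. For the measured compounds named here, the one measured step, an at least 31-fold lower number from compound 1 to compound 2 (1.49 log units; beyond the scatter), is large but concerns the amide-type nitrogen, so it bears only weakly here. Going by the values given here, no measured step isolates this aromatic carbon, so no clear direction is expected in this assay. The expected change is a 1.3-fold lower number from compound 3 to compound 4 (0.10 log units; within the scatter), within the scatter. Compound 4 is estimated at 1500 nM, with an expected range of 400 nM to 6000 nM.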

Compound 4, half-maximal inhibitory concentration: 4580 nM
For compound 4 the middle estimate is 3.1-fold (0.48 log units) below the measured one; the measured number falls inside the stated range.
By their numbers in this assay, from the lowest: compound 2; then compound 3; then compound 4. At a limit, above all of these: compound 1.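

In this assay the aromatic carbon now has its first measured step, a 2.4-fold higher number from compound 3 to compound 4 (0.38 log units; beyond the scatter), so the group held there does shift the read-out. The change alters both the substituent and its place on the phenyl ring, and the step cannot be split between the two. Nothing at hand gives a cause for this step.

Open, going by these compounds, is whether the same change reads alike with the 3-chlorobenzyl group of compound 2 on the nitrogen. Also open, on these data alone, is how an amine or a carboxylic acid on that phenyl ring would read.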